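Pyridin-2-yl in Place of Furan-3-yl on a Silent Series

The source may report more compounds than this note shows. Statements on the series, on what has been measured and on what is new or still open speak of the compounds shown alone.

Compound 3 `Oc1ccc(-c2cc(-c3ccoc3)cc(-c3ccccc3O)n2)cc1` reaches only a limit in a functional assay on T47D cells (Homo sapiens) for cytotoxicity, read by CCK-8 assay (on this read-out lower numbers stand for stronger inhibition and higher numbers for weaker inhibition), reported as > 50000 nM. Compound 1 `Oc1ccc(-c2cc(-c3cccs3)cc(-c3ccccc3O)n2)cc1` likewise gives only a limit, > 50000 nM. Compound 2 `Oc1ccc(-c2cc(-c3ccco3)cc(-c3ccccc3O)n2)cc1` also stops at a limit, > 50000 nM. Because of the limit of > 50000 nM in this assay, at which 3 of the 3 values shown sit, none of the three steps can be read: a step that the two limits leave unreadable from compound 1 to compound 2, a step that the two limits leave unreadable from compound 1 to compound 3 and a step that the two limits leave unreadable from compound 2 to compound 3 all stay unresolved. Compound 4 `Oc1ccc(-c2cc(-c3ccccn3)cc(-c3ccccc3O)n2)cc1` differs from compound 3 by pyridin-2-yl in place of furan-3-yl on an aromatic carbon. Going by the values given here, no measured step bears readably on this change, so the size expected for a number no higher from compound 3 to compound 4 (the limit leaves the size open) rests on the limits alone, with no direction beyond the scatter assumed. Compound 4 is therefore estimated at 50000 nM in this assay, within a range from 15000 nM to 150000 nM, and is expected most likely to appear once more only as a limit.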

Compound 4, half-maximal inhibitory concentration: > 50000 nM
Compound 4: no number, only a limit; the forecaster's own chance of this, stated with the estimate: 80%; the middle value lies on the limit itself.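

The steps linking compound 4 to compound 1, compound 2 and compound 3 cannot be read, for one cause: the limit of > 50000 nM in this assay, at which 4 of the 4 values shown sit. The compounds shown leave open whether any group at this place gives a measurable value in this assay.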